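Trading the Acetyl Group for Hydrogen on the Ring Oxygen

The source may hold more compounds than are shown below. What is called first, only, known or untested is meant among the compounds shown, and "the series" means these compounds.

Measured so far, in an assay on CHO cells for displacement of a labelled ligand from transmembrane domain-containing protein TMIGD3 (Homo sapiens); a higher number here means a weaker inhibitor, a lower number a stronger inhibitor:
- compound 1 `CC(=O)Oc1cccc2cc(-c3ccsc3)c(=O)oc12` gives 1820 nM
- compound 2 `CC(=O)Oc1cccc2cc(-c3cc(Br)cs3)c(=O)oc12` gives 4080 nM

Compound 2 has the higher of the two numbers in this assay, so it is the weaker binder of the pair; the step of a 2.2-fold higher number from compound 1 to compound 2 (0.35 log units; beyond the scatter) is modest but beyond the usual scatter. Compound 3 `O=c1oc2c(O)cccc2cc1-c1cc(Br)cs1` has not yet been measured. It differs from compound 2 by hydrogen in place of acetyl on an oxygen on an aromatic ring. Going by the values given here, no measured step touches this position: the one change recorded so far, that from compound 1 to compound 2, concerns the other ring, so it says nothing about what removing the acetyl group will do. With no guide from the measured pair, the expectation is simply that compound 3 stays near compound 2, with wide room either way, as a 1.0-fold lower number from compound 2 to compound 3 (0.01 log units; within the scatter) expresses. Compound 3 is therefore expected to give about 4000 nM in this assay, within a range of 1000 nM to 16000 nM.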

Compound 3, inhibition constant: 746 nM
Compound 3: the middle estimate sits 5.4-fold (0.73 log units) above what was measured; the measured number lies below the stated range.
By their numbers in this assay, from the lowest: compound 3; then compound 1; then compound 2.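

In this assay the change from acetoxy to hydroxy gives a 5.5-fold lower number from compound 2 to compound 3 (0.74 log units; beyond the scatter) and so makes compound 3 the stronger binder of this pair. Going by these compounds alone, this is the first sign that the group on this oxygen on an aromatic ring affects the reading, since the only earlier step changed a different place on the molecule, and here the acetyl group can leave without any loss of binding. No measurement shown here explains why the number falls.

Going by these compounds, whether hydroxy is specially favoured at this position remains open, as a methoxy group or an amine in its place would be needed to test that. On these data alone, it is also open whether the same step would appear with thiophen-3-yl in place of the 4-bromothiophen-2-yl group.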